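The compounds below may be only part of what the source reports. "The series", "measured", "known", "first", "only" and "open" are said of these compounds alone.

In a functional assay on KB cells (Homo sapiens) for antiproliferative activity (on this read-out lower numbers stand for stronger inhibition and higher numbers for weaker inhibition), compound 1 (`CCOC(c1ccc(OC)cc1)c1ccc(C(C)C)cc(=O)c1O`) gives 0.5 ug/mL and stands level with its nearest neighbour, compound 3 (`COc1ccc(C(c2ccc(C(C)C)cc(=O)c2O)c2oc(CO)cc(=O)c2O)cc1`), which gives 0.5 ug/mL at the digits shown. Compound 2 (`Oc1c(C(c2ccco2)c2ccc3cccnc3c2O)ccc2cccnc12`) gives < 0.3 ug/mL as its entry, and this is a limit of the assay, not a number.

The step under consideration leads to compound 4 (`CCOC(c1ccccc1)c1ccc(C(C)C)cc(=O)c1O`) and is a small edit of compound 1: hydrogen in place of methoxy on an aromatic carbon with hydrogen in place of methoxy on an aromatic carbon, that is, 4-methoxyphenyl to phenyl. Going by the values given here, no measured step touches this methoxy. Among the compounds with values here, the only measured step, no change at the digits printed from compound 1 to compound 3 (within the scatter), sits at a different place, on a saturated chain carbon bound to two aromatic carbons, and keeps the 4-methoxyphenyl intact. It bears on the present change only indirectly, showing that a large exchange elsewhere on the core left the read-out flat. No step beyond the scatter is therefore expected in this assay, and no direction can be argued with confidence.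

The estimated change is a 1.2-fold higher number from compound 1 to compound 4 (0.08 log units; within the scatter) and is expected to stay small. For compound 4 the expected value is 0.6 ug/mL with an estimated range from 0.2 ug/mL to 1.5 ug/mL in this read-out.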

Compound 4, half-maximal inhibitory concentration: < 0.3 ug/mL
Compound 4: no number, only a limit (the forecaster's own chance of this, stated with the estimate: 10%); at least 2.0-fold (0.30 log units) between middle value and limit.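

Hydrogen in place of methoxy, on an aromatic carbon para to a large group, is the first measured change at this place, and it gives an at least 1.6-fold lower number from compound 1 to compound 4 (0.22 log units; that floor lies within the scatter). In this assay compound 4 gives < 0.3 ug/mL, and this entry is a limit of the assay, not a number. The 4-methoxyphenyl of compound 1 is therefore not required to keep the read-out at this level, since plain phenyl loses no activity, but the full size of the step cannot be read, and only its floor is known, because the entry sits at the assay's limit: the limit of < 0.3 ug/mL in this assay, at which 2 of the 4 values shown sit.

Still open, on these data alone, is whether the step truly exceeds the scatter, which would take a number for compound 4 rather than a limit. With only methoxy and hydrogen shown at this place, the series also gives no indication of how an amine, a carboxylic acid or a longer chain such as butoxy on the same aromatic carbon would read.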